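The source may report more compounds than this note shows. Statements on the series, on what has been measured and on what is new or still open speak of the compounds shown alone.

Of the compounds shown here, three have so far been tested in an assay on isolated protein for inhibition of Indoleamine 2,3-dioxygenase 1 (Homo sapiens), with a stated time of 60 min, tested at 10 uM; on this read-out higher numbers stand for more inhibition at the one concentration tested (going by the name of the read-out) and lower numbers for less inhibition. Compound 1 `Clc1ccc2[nH]c(SCc3ccccc3Oc3ccccc3)nc2c1` gives 30%. Compound 2 `c1ccc(CCc2ccccc2CSc2ncc[nH]2)cc1` gives 19%, and compound 3 `Clc1ccc2oc(SCc3ccccc3CCc3ccccc3)nc2c1` gives 21%. On these numbers compound 1 stands highest of the three; compound 3 lies within the scatter of it, so the two cannot be told apart, while compound 2 lies beyond the scatter, a step down from compound 1. None of these three pairs differ in only one place, so no single change can be tied to a single shift in the numbers.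

Compound 4 `Clc1ccc2[nH]c(SCc3ccccc3SCc3ccccc3)nc2c1` has not yet been measured. It differs from compound 1 in one place: benzylsulfanyl in place of phenoxy on an aromatic carbon. Within the data shown here, with no measured step of this kind to lean on, the expectation is that the change should move the reading little, if at all, beyond the scatter, so the step of a number 2 percentage points lower from compound 1 to compound 4 (within the scatter) is expected to be small and in neither direction with confidence. Compound 4 is therefore estimated at 28%, with a likely range from 15% to 42%.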

Compound 4, a percentage reported as inhibition, at one concentration (the size of the read-out at that concentration, not a potency): 19%
Estimate against measurement, compound 4: 9 percentage points above; measured number inside the range.
By their numbers in this assay, from the lowest: compounds 2, 4, 3 and 1 (each within the scatter of the next, the first and the last beyond it).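

Among these compounds, this is the first step in this assay that ties a shift in the number to one single change: benzylsulfanyl in place of phenoxy, on an aromatic carbon ortho to a large group, gives a number 11 percentage points lower from compound 1 to compound 4 (beyond the scatter). The reading at this position therefore depends on which group it carries, even though the two groups count alike in rings, hydrogen-bond donors and hydrogen-bond acceptors. No measurement at hand explains the step.

The compounds shown leave open how a methoxy group, an amine or a carboxylic acid on the same carbon would read. They also leave open whether the same swap would give a similar step on another core, as it is seen here in one pair only.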